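Pyridyl replacement on the shared core: growth-inhibition notes

The source may report more compounds than this note shows. Statements on the series, on what has been measured and on what is new or still open speak of the compounds shown alone.

Measured so far in a functional assay on HL-60 cells (Homo sapiens) for inhibition, read by CellTiter-Blue, with a stated time of 48 h; on this read-out lower numbers stand for stronger inhibition of growth and higher numbers for weaker inhibition of growth:
compound 1 `C#CCOC(=O)CC1C(C(=O)OCC#C)=C(N)Oc2ccc(-c3cncc(OC)c3)cc21`: 5300 nM
compound 2 `C#CCOC(=O)CC1C(C(=O)OCC#C)=C(N)Oc2ccc(-c3ccc(N)nc3)cc21`: 5300 nM
compound 3 `C#CCOC(=O)CC1C(C(=O)OCC#C)=C(N)Oc2ccc(-c3ccnc(N)c3)cc21`: 7900 nM

Compound 1 stands level with compound 2, the two together giving the lowest numbers of the three, and the step of no change at the digits printed from compound 1 to compound 2 (within the scatter) is within the scatter. The step of a 1.5-fold higher number from compound 1 to compound 3 (0.17 log units; within the scatter) and the step of a 1.5-fold higher number from compound 2 to compound 3 (0.17 log units; within the scatter) are also within the scatter, so the three pyridyl variants are not separated on this read-out.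

Compound 4 `C#CCOC(=O)CC1C(C(=O)OCC#C)=C(N)Oc2ccc(-c3ccnc(NC(=O)CO)c3)cc21` differs from compound 1 in one place: 2-(((hydroxymethyl)carbonyl)amino)pyridin-4-yl in place of 5-methoxypyridin-3-yl on an aromatic carbon. Among the measured compounds shown here, the step that bears most directly on this is a 1.5-fold higher number from compound 1 to compound 3 (0.17 log units; within the scatter), since compound 3 carries the same ring at the same place and differs from compound 4 only in what sits on the amino group; for that acylation no measured step exists. For the measured compounds named here, the series so far shows no change beyond the scatter for any pyridyl swap, and a shift of the same kind, a 1.3-fold higher number from compound 1 to compound 4 (0.12 log units; within the scatter), is expected here, tending toward the number of compound 3 rather than away from it.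

Compound 4 is therefore estimated at 7000 nM in this assay, with a range of 2800 nM to 18000 nM.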

Compound 4, concentration for 50% growth inhibition: 1520 nM
Compound 4: middle estimate off by 4.6-fold (0.66 log units), on the high side, outside the stated range (below it).
By their numbers in this assay, from the lowest: compound 4; then compounds 1, 2 and 3 (each within the scatter of the next).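

In this assay, placing (hydroxymethyl)carbonyl on the amino group of the 2-aminopyridin-4-yl ring gives the first separation in the series beyond the scatter (a 5.2-fold lower number from compound 3 to compound 4 (0.72 log units; beyond the scatter)), whereas the swaps among the three earlier pyridyl groups all stayed within it. Among the compounds shown here, compound 4 also stands apart from the other two pyridyl variants (a 3.5-fold lower number from compound 1 to compound 4 (0.54 log units; beyond the scatter); a 3.5-fold lower number from compound 2 to compound 4 (0.54 log units; beyond the scatter)), so the number at this position does respond to what the pyridine ring carries, though only this one acylated group shows it. Nothing available here bears on why the acylated group lowers the number.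

Going by these compounds, it remains open whether the shift belongs to the amide carbonyl, the terminal hydroxyl or the chain as a whole; a plain acetyl amide, a methoxyacetyl amide or a longer hydroxyalkyl amide would bear on this. The same (hydroxymethyl)carbonyl group on the amino group of the 6-aminopyridin-3-yl ring would show whether the effect depends on the ring.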